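The source may hold more compounds than are shown below. What is called first, only, known or untested is meant among the compounds shown, and "the series" means these compounds.

Measured so far in a functional assay on T47D cells (Homo sapiens) for cytotoxicity, read by MTT assay, with a stated time of 24 h; on this read-out lower numbers stand for stronger inhibition and higher numbers for weaker inhibition:

- compound 1, `COc1ccc(/C=C\C(=O)O)c(OCc2cn(-c3ccc(NC(=O)c4ccccc4)cc3)nn2)c1CC=C(C)C`, gives 23300 nM
- compound 2, `COc1ccc(/C=C\C(=O)O)c(OCc2cn(-c3ccc(CO)cc3)nn2)c1CC=C(C)C`, gives 40000 nM

Within the data shown here, compound 2 is one of only two measured compounds, and the single step to its neighbour, a 1.7-fold higher number from compound 1 to compound 2 (0.23 log units; within the scatter), lies within the scatter, so the two numbers cannot be told apart. Both sit at the weak end of what this read-out usually covers.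

Compound 3, `COc1ccc(/C=C\C(=O)O)c(OCc2cn(-c3ccccc3C#N)nn2)c1CC=C(C)C`, has not yet been measured. It differs from compound 2 in one place: 2-cyanophenyl in place of 4-(hydroxymethyl)phenyl on an aromatic nitrogen. Among the measured compounds shown here, the only measured step that bears on this change is the one from compound 1 to compound 2, which also swapped the group on that same phenyl ring and left the number essentially unchanged. There is no information on a group attached where the 2-cyanophenyl carries its nitrile, so nothing in the data points to a direction. The expectation for compound 3 in this assay is therefore a step of about a 1.1-fold lower number from compound 2 to compound 3 (0.06 log units; within the scatter), that is, none beyond the scatter. Compound 3 is estimated at 35000 nM, with a range of roughly 14000 nM to 85000 nM.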

Compound 3, half-maximal inhibitory concentration: 8800 nM
Beside the measured number, compound 3's estimate is 4.0-fold (0.60 log units) above it, outside the stated range (below it).
By their numbers in this assay, from the lowest: compound 3; then compounds 1 and 2 (each within the scatter of the next).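

In this assay, the group on the aromatic nitrogen can move the number beyond the scatter: 2-cyanophenyl in place of 4-(hydroxymethyl)phenyl gives a 4.5-fold lower number from compound 2 to compound 3 (0.66 log units; beyond the scatter) while the earlier change on this ring gave only a 1.7-fold higher number from compound 1 to compound 2 (0.23 log units; within the scatter) and could not be told from noise. Two things differ together in the new step, the kind of group on the phenyl ring (a nitrile in place of a hydroxymethyl) and its place on that ring (2 rather than 4 in the group's name), so the step cannot be credited to either one alone. No measurement shown here offers an explanation for this step.

Still open, from the compounds shown here alone, is whether the nitrile or its place on the ring matters more, and whether a different group on that ring, such as an amine or a methyl, would lower the number as well. Also open, going by these compounds, is whether the step would hold on a changed core, for instance with an ester in place of the carboxylic acid.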